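The source may hold more compounds than are shown below. What is called first, only, known or untested is meant among the compounds shown, and "the series" means these compounds.

Compound 1 `Cc1nn(-c2ncnc3nc[nH]c23)c2c1C(C(=O)Nc1ccccc1)CC(=O)N2`: 10 nM
Compound 2 `C/C(=N\NC(=O)c1cc2ccccc2cc1O)c1ccc(N)cc1`: 1100 nM
Compound 3 `Cc1nn(-c2ncnc3nc[nH]c23)c2c1C(OCc1ccccc1F)CC(=O)N2`: 4 nM

In a functional assay on HEK293 cells for agonist activity at G-protein coupled receptor 39 (Homo sapiens), read by scintillation proximity assay and inositol phosphate accumulation, with a stated time of 75 min, in the presence of a further agent that is not named here (a higher number here means that more compound is needed for the effect, a lower number that less compound is needed), compound 1 gives 10 nM, the second highest of the three numbers. Its nearest neighbour is compound 3, which gives 4 nM, and the most distant is compound 2, a compound of a different scaffold, which gives 1100 nM.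

The unmeasured compound 4 `Cc1nn(-c2ncnc3nc[nH]c23)c2c1C(OCc1ccccc1C#N)CC(=O)N2` keeps the shared core of compound 1 and differs from it in one place: (2-cyanobenzyl)oxy in place of phenylcarbamoyl on a saturated ring carbon. Among the measured compounds shown here, only one measured step bears on this change. Replacing the same phenylcarbamoyl group with a (2-fluorobenzyl)oxy group gave a 2.5-fold lower number from compound 1 to compound 3 (0.40 log units; beyond the scatter). Compound 4 carries a (2-cyanobenzyl)oxy group instead, so it is a benzyl ether of the same kind, bearing a nitrile where compound 3 bears a fluorine. For the measured compounds named here, there is no measured pair that shows what swapping fluorine for a nitrile does on this core.

Compound 4 is therefore expected to land near compound 3 rather than near compound 1, with an estimated step of a 1.7-fold lower number from compound 1 to compound 4 (0.22 log units; within the scatter). The estimate for compound 4 in this assay is 6 nM, with a range from 2 nM to 20 nM.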

Compound 4, half-maximal effective concentration: 8 nM
Compound 4: the middle estimate sits 1.3-fold (0.12 log units) below what was measured; the range from low to high includes it.
By their numbers in this assay, from the lowest: compounds 3, 4 and 1 (each within the scatter of the next, the first and the last beyond it); then compound 2.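

Replacing phenylcarbamoyl with (2-cyanobenzyl)oxy on this saturated ring carbon gives a 1.3-fold lower number from compound 1 to compound 4 (0.10 log units; within the scatter), whereas the fluorinated ether of compound 3 had differed from compound 1 by more than the scatter, so a shift beyond the scatter does not hold for both benzyl ethers. Exchanging fluoro for cyano on the aromatic carbon gives a 2.0-fold higher number from compound 3 to compound 4 (0.30 log units; within the scatter), so these two benzyl ethers cannot be told apart in this measurement, and the position accepts either group on the ring. No information is available on why these groups give such similar numbers.

What the compounds shown leave open is whether a plain benzyl ether with nothing on its ring, or one carrying a methoxy group or an amine instead of the fluoro or cyano group, would also stay in this range. Going by these compounds, it also remains open whether a longer chain linking the oxygen to the aromatic ring would be accepted on this saturated ring carbon.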